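Sulfonyl Substituent Swap in a Nicotinamide Phosphoribosyltransferase Series

A few compounds are considered here, and "the series" means these few. Any claim that something is new, unique, unknown or untested is made for them only; others in the source may bear on it.

Compound 1 `O=C(NCc1ccc(S(=O)(=O)c2cc(F)cc(F)c2)cc1)N1Cc2ccncc2C1` gives 7.1 nM in an assay on isolated protein for inhibition of Nicotinamide phosphoribosyltransferase (Homo sapiens), read by mass spectrometry, with stated times of 15 min and 30 min; on this read-out lower numbers stand for stronger inhibition and higher numbers for weaker inhibition. Among the compounds with values here, compound 2 `CC(=O)N1CCC(S(=O)(=O)c2ccc(CNC(=O)N3Cc4ccncc4C3)cc2)CC1` gives 83 nM in this assay, the higher of the two numbers, and the single known step of a 12-fold higher number from compound 1 to compound 2 (1.07 log units; beyond the scatter) separates them. Compound 3 `O=C(NCc1ccc(S(=O)(=O)N2CCC(O)CC2)cc1)N1Cc2ccncc2C1` differs from compound 2 by 4-hydroxypiperidin-1-yl in place of 1-acetylpiperidin-4-yl on a sulfonyl sulfur. Within the data shown here, no measured step exchanges one saturated ring for another on this sulfur; the one step known is large but concerns an aromatic group leaving, so it offers no direct guide. Compound 3 is therefore expected to show only a small step of a 1.4-fold higher number from compound 2 to compound 3 (0.16 log units; within the scatter) in this assay. Compound 3 is estimated at 120 nM, ranging from 40 nM to 400 nM.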

Compound 3, half-maximal inhibitory concentration: 44 nM
For compound 3 the middle estimate is 2.7-fold (0.44 log units) above the measured one, and the stated range covers the measured number.
By their numbers in this assay, from the lowest: compound 1; then compounds 3 and 2 (each within the scatter of the next).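

In this assay the exchange of 1-acetylpiperidin-4-yl for 4-hydroxypiperidin-1-yl on the sulfonyl sulfur gives a 1.9-fold lower number from compound 2 to compound 3 (0.28 log units; within the scatter) and thus no separable difference between these two saturated rings. Set against 3,5-difluorophenyl, 4-hydroxypiperidin-1-yl gives a 6.2-fold higher number from compound 1 to compound 3 (0.79 log units; beyond the scatter) and so, like 1-acetylpiperidin-4-yl, stays separated from the aromatic group by more than the scatter. No measured evidence is available to explain either step. The compounds shown leave open how a phenyl group without fluorine would compare with 3,5-difluorophenyl on this sulfur. They also leave open whether a 4-aminopiperidin-1-yl group or a carboxylic acid on the piperidine ring would stay level with 4-hydroxypiperidin-1-yl.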